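A few compounds are considered here, and "the series" means these few. Any claim that something is new, unique, unknown or untested is made for them only; others in the source may bear on it.

Compounds measured so far:
compound 1, `Cc1cc(C)cc(NN=C2CCC(C)n3c2ncc(C(=O)O)c3=O)c1`, in a functional assay on the whole organism with Rattus norvegicus as the target; a higher number here means that more compound is needed for the effect, a lower number that less compound is needed: > 320 umol/kg
compound 2, `Cc1cc(C)c(NN=C2CCC(C)n3c2ncc(C(=O)O)c3=O)cc1C`, in this assay: 320 umol/kg

Compound 1 stands at a limit of this assay: its value of > 320 umol/kg is a limit and not a number, so its place among the values is known only as a bound (the limit of > 320 umol/kg in this assay, at which 1 of the 2 values shown sits). Compound 2 gives a measured value of 320 umol/kg in this assay. Going by the values given here, no step between the two compounds is given, and the two values show only where each of them stands on its own.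

The step from compound 1 to compound 3, `Cc1cccc(Cl)c1NN=C1CCC(C)n2c1ncc(C(=O)O)c2=O`, changes the group on the amine nitrogen: 2-chloro-6-methylphenyl in place of 3,5-dimethylphenyl on an amine nitrogen. Among the compounds with values here, no measured step between compounds tells what size of change to expect in this assay here; with compound 1 only bounded, the account expects no change beyond the scatter, and compound 3 may well be reported only as a limit as well. Compound 3 is therefore estimated at 250 umol/kg, with a range from 80 umol/kg to 800 umol/kg. The expected step of an at least 1.2-fold lower number from compound 1 to compound 3 (0.10 log units; that floor lies within the scatter) is small.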

Compound 3, dose for 50% inhibition: > 100 umol/kg
Compound 3: only a limit was reported; the forecaster's own chance of this, stated with the estimate: 45%; the middle value lies beyond the limit too.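

In this assay compound 3 gives > 100 umol/kg, which is a limit and not a number. Compound 1 gives > 320 umol/kg, also a limit. No step can be read from compound 1 to compound 3. The compounds shown leave open whether 2-chloro-6-methylphenyl in place of 3,5-dimethylphenyl on an amine nitrogen changes the dose needed.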